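Shortening the alkyl chain on compound 2

A few compounds are considered here, and "the series" means these few. Any claim that something is new, unique, unknown or untested is made for them only; others in the source may bear on it.

Measured compounds:
- compound 1 `COc1ccc(F)c(-c2ccc(COc3cccc([C@@H](CC(=O)O)C4CC4)c3)nc2CC(C)(C)C)c1`: 150 nM
- compound 2 `COc1ccc(CCCC(C)(C)C)c(N2CCC(COc3cccc(C(CC(=O)O)C4CC4)c3)CC2)c1`: 11 nM
- compound 3 `COc1ccc(C)c(N2CCC(COc3cccc(C(CC(=O)O)C4CC4)c3)CC2)c1`: 270 nM

In a functional assay on cells for agonist activity at Free fatty acid receptor 1 (Homo sapiens), read by FLIPR and calcium flux, with a stated time of 60 min (a lower number here means that less compound is needed, a higher number that more compound is needed for the effect), compound 2 gives the lowest number of the three; compound 1 is its nearest neighbour and compound 3 the furthest. The unmeasured compound 4 `COc1ccc(CCC(C)(C)C)c(N2CCC(COc3cccc(C(CC(=O)O)C4CC4)c3)CC2)c1` differs from compound 2 by a single change: tert-butyl in place of neopentyl on a saturated chain carbon, two bonds along the chain from an aromatic carbon. In other words, the chain on the aromatic ring is cut shorter by one carbon but keeps its branched end.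

For the measured compounds named here, the one measured step that speaks to this is the removal of almost the whole chain, a 25-fold higher number from compound 2 to compound 3 (1.39 log units; beyond the scatter), which cost a great deal of activity. Compound 4 keeps most of that chain, so only a small part of such a loss, if any, is expected. The step from compound 2 to compound 4 is therefore estimated as a 2.0-fold higher number from compound 2 to compound 4 (0.30 log units; within the scatter), a change that may stay within the scatter. Compound 4 is expected to give about 22 nM in this assay, with a likely range from 7 nM to 70 nM.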

Compound 4, half-maximal effective concentration: 34 nM
Compound 4: the middle estimate sits 1.5-fold (0.19 log units) below what was measured; the measured number falls inside the stated range.
By their numbers in this assay, from the lowest: compound 2; then compound 4; then compounds 1 and 3 (each within the scatter of the next).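

In this assay, the loss at this position does not need the whole chain to go: tert-butyl in place of neopentyl, on a saturated chain carbon two bonds along the chain from an aromatic carbon, gives a 3.1-fold higher number from compound 2 to compound 4 (0.49 log units; beyond the scatter) and so already lies beyond the scatter. Much of the chain's benefit still survives this cut, as neopentyl in place of hydrogen on a saturated chain carbon bound to an aromatic carbon gives a 7.9-fold lower number from compound 3 to compound 4 (0.90 log units; beyond the scatter) and shows. Across compound 3, compound 4 and compound 2, the number falls as the chain grows, and none of these three goes against that order.

Going by these compounds, whether a longer chain such as 5,5-dimethylhexyl would lower the number further, or an unbranched butyl chain would match the branched end, stays open. Nothing available explains why chain length has this effect.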